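Trading a Dienyl Amide for an Isopropyl Amide

The source may hold more compounds than are shown below. What is called first, only, known or untested is meant among the compounds shown, and "the series" means these compounds.

Three amides built on a shared core, with a benzyl group on the amide nitrogen, were tested in a functional assay on HCT-116 cells (Homo sapiens) for inhibition, read by MTT assay, with a stated time of 48 h; a lower number here means a stronger inhibitor, a higher number a weaker inhibitor. Compound 1, `C/C=C/C(=O)N(Cc1cccc(O)c1)c1cc(OC)c(OC)c(OC)c1`, gives 6700 nM. Compound 3, `C/C=C/C(=O)N(Cc1ccc(OC)c([N+](=O)[O-])c1)c1cc(OC)c(OC)c(OC)c1`, gives 670 nM. Compound 2, `C/C=C/C=C/C(=O)N(Cc1ccc(OC)c(O)c1)c1cc(OC)c(OC)c(OC)c1`, gives 180 nM, the lowest of the three numbers and beyond the scatter from both of the others, so it stands as the strongest inhibitor of this set.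

The next compound, compound 4, `COc1ccc(CN(C(=O)C(C)C)c2cc(OC)c(OC)c(OC)c2)cc1O`, has not yet been measured in this assay. It differs from compound 2 in one place: isopropyl in place of penta-1,3-dien-1-yl on a carbonyl carbon. Among the compounds with values here, no pair of measured compounds differs in exactly this way, so the size of the step cannot be read directly from the data. What the three numbers do show is that compound 2, the one with the longer unsaturated chain on the carbonyl carbon, gives the lowest number, while compound 1, with a shorter chain and a different phenol, gives a far higher one.

On that basis compound 4 is expected to be a weaker inhibitor than compound 2, with the estimated step of a 14-fold higher number from compound 2 to compound 4 (1.14 log units; beyond the scatter) going upward and beyond the scatter. The expected value for compound 4 in this assay is 2500 nM, within a range from 500 nM to 12000 nM.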

Compound 4, half-maximal inhibitory concentration: 310 nM
Compound 4: middle estimate off by 8.1-fold (0.91 log units), on the high side; measured number below the stated range.
By their numbers in this assay, from the lowest: compounds 2 and 4 (each within the scatter of the next); then compound 3; then compound 1.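

Within the data shown here, compound 4 gives the first direct reading of this position, since no two earlier compounds differed only in the group on the carbonyl carbon. In this assay, placing isopropyl where penta-1,3-dien-1-yl stood gives a 1.7-fold higher number from compound 2 to compound 4 (0.24 log units; within the scatter), so the two compounds cannot be told apart in this assay. For this pair, then, the 2 double bonds outside aromatic rings and the longer unsaturated chain are not required for a number in this range, and nothing available explains why the exchange makes so little difference.

The compounds shown leave open how far this tolerance extends on the carbonyl carbon, for instance to a methyl, a tert-butyl, a cyclopropyl or a longer saturated chain such as n-pentyl, or to a group carrying an amine or a carboxylic acid. They also leave open whether isopropyl in place of penta-1,3-dien-1-yl would give a similar step with a different substituted benzyl group on the amide nitrogen, since this one pair shares a single benzyl group.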